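The source may hold more compounds than are shown below. What is called first, only, known or untested is meant among the compounds shown, and "the series" means these compounds.

In a functional assay on the whole organism (strain Swiss albino) for inhibition, with Mus musculus as the target, read by paw edema, with stated times of 30 min and 360 min, at a dose of 100 mg/kg by the subcutaneous route (on this read-out lower numbers stand for less inhibition and higher numbers for more inhibition at the one dose given (going by the name of the read-out)), compound 1 `CCOC(=O)C1CCN(C(=O)c2cc(-c3ccc(C)cc3)nn2Cc2ccccc2)CC1` gives 57.6%, while compound 2 `Cc1ccc(-c2cc(C(=O)NCc3cccnc3)n(Cc3ccccc3)n2)cc1` gives 25.3%, the lower of the two numbers, with a gap to compound 1 beyond the usual scatter. Compound 3 `Cc1ccc(-c2cc(C(=O)NNc3ccc4ccccc4n3)n(Cc3ccccc3)n2)cc1` is not yet measured in this assay. Its change from compound 2: (quinolin-2-yl)amino in place of (pyridin-3-yl)methyl on an amide-type nitrogen. Among the measured compounds shown here, no measured pair shows this change, so nothing in the numbers so far tells its direction. A modest rise in this assay is nonetheless expected, a step of a number 14.7 percentage points higher from compound 2 to compound 3 (beyond the scatter). Compound 3 is expected near 40%, within a range from 15% to 65%.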

Compound 3, a percentage reported as inhibition, in the whole organism at one dose (the size of the read-out at that dose, not a potency): 42.8%
Estimate against measurement, compound 3: 2.8 percentage points below; low and high end bracket the measured number.
By their numbers in this assay, from the lowest: compound 2; then compound 3; then compound 1.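

On the amide-type nitrogen, with the carbonyl carbon as its other neighbour, (quinolin-2-yl)amino in place of (pyridin-3-yl)methyl gives a number 17.5 percentage points higher from compound 2 to compound 3 (beyond the scatter) in this assay. Among the compounds shown here, this is the first single-place change, and it shows that the read-out responds to the group at this position. Nothing measured here gives a cause for the step. Open, on these data alone, is whether the rise follows the added carbon-only ring or the amino nitrogen; a phenylamino group and a quinolin-2-ylmethyl group on the same nitrogen would separate the two.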